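A few compounds are considered here, and "the series" means these few. Any claim that something is new, unique, unknown or untested is made for them only; others in the source may bear on it.

Series note. Compound 1 `Cc1ccc(-c2nn(-c3ccccc3)cc2-c2nc3ccccc3n2S(=O)(=O)c2ccc(Br)cc2)cc1` gives 3040 nM in a functional assay on HepG2 cells (Homo sapiens) for antiproliferative activity, read by MTT assay, with a stated time of 24 h; a higher number here means a weaker inhibitor, a lower number a stronger inhibitor. Compound 2 `Cc1ccc(-c2nn(-c3ccccc3)cc2-c2nc3ccccc3n2S(=O)(=O)c2ccc(C(F)(F)F)cc2)cc1` gives 1930 nM in this assay; the step of a 1.6-fold lower number from compound 1 to compound 2 (0.20 log units; within the scatter) goes with trifluoromethyl in place of bromo on an aromatic carbon. Compound 3 `O=S(=O)(c1ccc(Br)cc1)n1c(-c2cn(-c3ccccc3)nc2-c2ccc(C(F)(F)F)cc2)nc2ccccc21` gives 2160 nM in this assay; its core differs from that of compound 1 by trifluoromethyl in place of methyl on an aromatic carbon, with the step of a 1.4-fold lower number from compound 1 to compound 3 (0.15 log units; within the scatter). Compound 4 `O=S(=O)(c1ccc(C(F)(F)F)cc1)n1c(-c2cn(-c3ccccc3)nc2-c2ccc(C(F)(F)F)cc2)nc2ccccc21` is not yet measured in this assay. It differs from compound 3 by trifluoromethyl in place of bromo on an aromatic carbon, the same change made from compound 1 to compound 2, at the same kind of place. A step of similar size is expected here, a 1.5-fold lower number from compound 3 to compound 4 (0.19 log units; within the scatter), resting on the earlier step because a 1.6-fold lower number from compound 1 to compound 2 (0.20 log units; within the scatter) was small and within the scatter. For compound 4 the estimate in this assay is 1400 nM, expected to fall between 700 nM and 2800 nM.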

Compound 4, half-maximal inhibitory concentration: 1120 nM
Beside the measured number, compound 4's estimate is 1.3-fold (0.10 log units) above it; measured number inside the range.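

In this assay, trifluoromethyl in place of bromo gives a 1.9-fold lower number from compound 3 to compound 4 (0.29 log units; within the scatter), and this step agrees with the earlier one on the other core: the same change on two cores in this assay, a 1.6-fold lower number (0.20 log units; within the scatter) from compound 1 to compound 2 and a 1.9-fold lower number (0.29 log units; within the scatter) from compound 3 to compound 4, 1.2-fold (0.09 log units) apart, within the scatter of two such steps. Trifluoromethyl in place of methyl gives a 1.7-fold lower number from compound 2 to compound 4 (0.24 log units; within the scatter), and this step also agrees with its earlier counterpart: the same change on two cores in this assay, a 1.4-fold lower number (0.15 log units; within the scatter) from compound 1 to compound 3 and a 1.7-fold lower number (0.24 log units; within the scatter) from compound 2 to compound 4, 1.2-fold (0.09 log units) apart, within the scatter of two such steps. Each change therefore carries across these two cores without a detectable difference, but every step lies within the scatter, so this does not show that either change alters activity or that the agreement extends to other cores.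

The compounds shown carry only bromo, methyl and trifluoromethyl at the two varied places. On these data alone, what an amine, a carboxylic acid or a longer chain would do at either place remains open.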